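A few compounds are considered here, and "the series" means these few. Any claim that something is new, unique, unknown or untested is made for them only; others in the source may bear on it.

Measured compounds:
compound 1, `CN(C)CCn1nc(Cc2ccc(Cl)cc2)c2ccccc2c1=O`, 158 nM
compound 2, `COc1cccc(Cc2nn(C[C@H]3CCCN3C)c(=O)c3ccccc23)c1`, 1580 nM
compound 3, `CN1CCC(Cn2nc(Cc3ccc(Cl)cc3)c3ccccc3c2=O)C1`, 100 nM

In an assay for binding affinity to Alpha-1A adrenergic receptor (Homo sapiens) (a lower number here means a stronger inhibitor, a higher number a weaker inhibitor), compound 2 gives 1580 nM, the highest of the three numbers; compound 1, with 158 nM, and compound 3, with 100 nM, both lie well beyond the scatter from it. Compound 4, `CN1CCC[C@@H]1Cn1nc(Cc2ccc(F)c(F)c2)c2ccccc2c1=O`, has not been measured. Against compound 2 it shows one change: 3,4-difluorophenyl in place of 3-methoxyphenyl on a saturated chain carbon bound to an aromatic carbon.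

Going by the values given here, no measured step touches this part of the molecule. Among the compounds with values here, the only step with a single change, a 1.6-fold lower number from compound 1 to compound 3 (0.20 log units; within the scatter), concerns the saturated chain bound to the aromatic nitrogen and lies within the scatter, so it says nothing about the aromatic group that is swapped here. What the values of compound 1 and compound 3 do show is that both compounds, whose aromatic group carries a chlorine atom rather than a methoxy group, give far lower numbers than compound 2, though each also differs from compound 2 in the saturated chain, so no clean comparison exists.

With that caveat, the number for compound 4 is expected to fall, a step of about a 4.0-fold lower number from compound 2 to compound 4 (0.60 log units; beyond the scatter), toward the region of compound 1 and compound 3. The estimate for compound 4 is 400 nM, in a range from 130 nM to 1300 nM.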

Compound 4, inhibition constant: 200 nM
Estimate against measurement, compound 4: 2.0-fold (0.30 log units) above, and the stated range covers the measured number.
By their numbers in this assay, from the lowest: compounds 3, 1 and 4 (each within the scatter of the next); then compound 2.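

In this assay, going by these compounds alone, putting 3,4-difluorophenyl in place of 3-methoxyphenyl on a saturated chain carbon bound to an aromatic carbon gives a 7.9-fold lower number from compound 2 to compound 4 (0.90 log units; beyond the scatter), and this is the first step in which the aromatic group changes while the rest of the molecule stays the same. The earlier compounds shown here that differ from compound 2 in this group also differ from it in the saturated chain, so they could not show that this group alone can move the number beyond the scatter. The swap also replaces a group with one hydrogen-bond acceptor by one with none at the same heavy-atom count, but no measurement at hand explains why the number falls.

Since both fluorines enter together, the compounds shown leave open what a plain phenyl, or a phenyl carrying a single fluorine, would give at this place. Also open, as far as these compounds go, is whether the same swap would produce a step of similar size on a different chain, such as the (dimethylamino)methyl chain of compound 1.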